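A few compounds are considered here, and "the series" means these few. Any claim that something is new, unique, unknown or untested is made for them only; others in the source may bear on it.

In an ADME assay on CEM-SS cells (Homo sapiens) for cytotoxicity, read by XTT assay (a higher number here means that more compound is tolerated, a lower number that less compound is tolerated), compound 2 `Cc1cccc(Cn2cc(Nc3ccccc3)c(=O)[nH]c2=O)c1` gives > 200000 nM, which is a limit of the assay and not a number. Compound 1 `O=c1[nH]c(=O)n(Cc2ccccc2)cc1Nc1ccccc1` differs from compound 2 by a single methyl. In this assay compound 1 gives > 100000 nM, again a limit rather than a measured number. The step that the two limits leave unreadable from compound 1 to compound 2 therefore cannot be read in size or direction: the two values are described by the limit of > 100000 nM in this assay, at which 1 of the 2 values shown sits, and by the limit of > 200000 nM in this assay, at which 1 of the 2 values shown sits, and nothing in between is known. Compound 3 `Cc1cc(C)cc(Cn2cc(Nc3ccccc3)c(=O)[nH]c2=O)c1` carries the same kind of change one stage further, (methyl in place of hydrogen on an aromatic carbon). Among the measured compounds shown here, the only measured step of this kind, the one from compound 1 to compound 2, bears on it, and that step left no readable size. No step beyond the scatter is expected in this assay, and the most likely outcome for compound 3 is expected to be a third limit. The step that the limit leaves unreadable from compound 2 to compound 3 is expected to stay within the scatter. Compound 3 is expected to give 250000 nM in this assay, with a range from 120000 nM to 500000 nM.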

Compound 3, half-maximal cytotoxic concentration: > 200000 nM
Compound 3: a limit, no number (the forecaster's own chance of this, stated with the estimate: 85%); the middle value does not contradict the limit.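

In this assay compound 3 gives > 200000 nM, which is a limit of the assay and not a number. The steps to compound 3 from compound 1 and from compound 2 cannot be read in size or direction. The compounds shown leave open at what concentration any of the three becomes cytotoxic, and whether the added methyl groups change that concentration.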